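Two Ortho Chlorines Where a Hydroxy Once Stood

The compounds below may be only part of what the source reports. "The series", "measured", "known", "first", "only" and "open" are said of these compounds alone.

Going by the values given here, compound 2 `O=C(Cc1csc2nc(-c3ccc(Br)cc3)cn12)N/N=C/c1ccccc1O` gives 13800 nM in a functional assay on DU-145 cells (Homo sapiens) for inhibition, read by sulforhodamine B assay, with a stated time of 48 h (a lower number here means a stronger inhibitor of growth, a higher number a weaker inhibitor of growth), the lowest of the three numbers measured so far. Compound 1 `O=C(Cc1csc2nc(-c3ccc(Br)cc3)cn12)N/N=C/c1ccccc1` gives 44700 nM, and compound 3 `COc1cccc(OC)c1/C=N/NC(=O)Cc1csc2nc(-c3ccc(Br)cc3)cn12` gives 47900 nM in this assay. Compound 4 `O=C(Cc1csc2nc(-c3ccc(Br)cc3)cn12)N/N=C/c1ccc(Cl)cc1Cl` has not been measured; it differs from compound 2 by 2,4-dichlorophenyl in place of 2-hydroxyphenyl on a carbon with a double bond to nitrogen. Among the compounds with values here, two measured steps bear on this change. a 3.2-fold lower number from compound 1 to compound 2 (0.51 log units; beyond the scatter) accompanied hydroxy in place of hydrogen; a 3.5-fold higher number from compound 2 to compound 3 (0.54 log units; beyond the scatter) accompanied 2,6-dimethoxyphenyl in place of 2-hydroxyphenyl. Compound 4 carries no hydroxy group. Because compound 1 stands at 44700 nM and compound 3 at 47900 nM, a step toward those numbers is expected for compound 4, a 2.5-fold higher number from compound 2 to compound 4 (0.40 log units; beyond the scatter). The estimate for compound 4 is 35000 nM, within 12000 nM to 100000 nM.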

Compound 4, concentration for total growth inhibition: > 100000 nM
Compound 4: a limit, no number; the forecaster's own chance of this, stated with the estimate: 10%; middle value at least 2.8-fold (0.45 log units) from the limit.
By their numbers in this assay, from the lowest: compound 2; then compounds 1 and 3 (each within the scatter of the next). At a limit, above all of these: compound 4.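

In this assay, compound 4 gives a limit and not a number: the limit of > 100000 nM in this assay, at which 1 of the 4 values shown sits. The earlier compounds shown here suggested that this position turned on the presence of hydroxy, yet the change to 2,4-dichlorophenyl goes beyond the loss of that group alone, with an at least 7.2-fold higher number from compound 2 to compound 4 (0.86 log units; beyond the scatter). Compound 1 and compound 3 also carry no hydroxy, and 2,4-dichlorophenyl still separates from both, with an at least 2.2-fold higher number from compound 1 to compound 4 (0.34 log units; beyond the scatter) and an at least 2.0-fold higher number from compound 3 to compound 4 (0.31 log units; beyond the scatter).

The compounds shown leave open whether a single chlorine would give the same step. They also leave open how an amine or a carboxylic acid on the phenyl ring would read here.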